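The compounds below may be only part of what the source reports. "The series", "measured", "known", "first", "only" and "open" are said of these compounds alone.

Values measured in an in vitro functional assay on HEK285-7 cells for antagonist activity at prostaglandin D2 receptor 2 (Homo sapiens), read by BRET and beta-arrestin recruitment; on this read-out lower numbers stand for stronger inhibition and higher numbers for weaker inhibition:

compound 1, `O=C(O)Cc1sc(C(c2ccc(F)cc2)c2ccc(F)cc2)nc1-c1cc(F)cc(F)c1`: compound 1 gives 340 nM
compound 2, `O=C(O)Cc1sc(C(c2ccc(F)cc2)c2ccc(F)cc2)nc1-c1ccoc1`: compound 2 gives 130 nM
compound 3, `Cc1cc(-c2nc(C(c3ccc(F)cc3)c3ccc(F)cc3)sc2CC(=O)O)ccn1`: compound 3 gives 53 nM

Compound 3 holds the lowest number of the three. The step of a 6.4-fold lower number from compound 1 to compound 3 (0.81 log units; beyond the scatter) and the step of a 2.5-fold lower number from compound 2 to compound 3 (0.39 log units; beyond the scatter) both lie beyond the scatter, so compound 3 is the strongest inhibitor in this assay among the measured set; the step of a 2.6-fold lower number from compound 1 to compound 2 (0.42 log units; beyond the scatter) separates the other two.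

Compound 4, `O=C(O)Cc1sc(C(c2ccc(F)cc2)c2ccc(F)cc2)nc1-c1ccnc(N2CCC2)c1`, differs from compound 3 in one place: azetidin-1-yl in place of methyl on an aromatic carbon. Among the compounds with values here, none of the measured steps bears directly on this change. Each of them exchanges the whole aryl group on the shared core, and in none of them is the 2-methylpyridin-4-yl group itself modified. What the three steps show is that exchanging the aryl group moves the number within a modest spread, and that the 2-methylpyridin-4-yl group gives the lowest value. Within the data shown here, with no precedent for the azetidin-1-yl group, the expectation for compound 4 is a step of modest size at most, direction uncertain, centred on no change beyond the scatter: a 1.1-fold lower number from compound 3 to compound 4 (0.03 log units; within the scatter) is the expected step. Compound 4 is estimated at 50 nM in this assay, with a range from 15 nM to 160 nM.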

Compound 4, half-maximal inhibitory concentration: > 100000 nM
Compound 4: only a limit was reported; the forecaster's own chance of this, stated with the estimate: 0%; at least 2000-fold (3.30 log units) between middle value and limit.
By their numbers in this assay, from the lowest: compound 3; then compound 2; then compound 1. At a limit, above all of these: compound 4.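

The carbon next to the ring nitrogen is a highly sensitive position in this assay: azetidin-1-yl in place of methyl, a four-membered non-aromatic ring of 4 heavy atoms entering for 1 heavy atom, gives an at least 1800-fold higher number from compound 3 to compound 4 (3.27 log units; beyond the scatter). This one change on the 2-methylpyridin-4-yl group far outweighs the modest exchanges of the whole aryl group among compound 1, compound 2 and compound 3, and the 2-(azetidin-1-yl)pyridin-4-yl group also stands far from the other two aryl groups, with an at least 760-fold higher number from compound 2 to compound 4 (2.88 log units; beyond the scatter) and an at least 290-fold higher number from compound 1 to compound 4 (2.46 log units; beyond the scatter). For compound 4 only a limit is recorded, so the steps to it are bounds rather than measured sizes, and the data give no cause for the loss: the limit of > 100000 nM in this assay, at which 1 of the 4 values shown sits.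

Going by these compounds, it remains open whether the loss goes with the azetidine ring itself or with any amine at this carbon, which a dimethylamino group or a methoxy group at the same place would help to separate. Equally open, on these data alone, is how an ethyl or cyclopropyl group there would compare with the methyl of compound 3 at 53 nM.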